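Alkyl tail variation on the phenyl-ketone side of the series

This account rests on a few compounds, and the source may have more. Where it says the series, first, only, none or still open, it means among the compounds named here.

Compound 3 `Cc1cc(OCCCCOc2ccc(C(=O)CC(C)C)c(O)c2C)ccc1C(=O)O` gives the highest number of the three measured in an assay on HEK293 cells for positive allosteric modulation of metabotropic glutamate receptor 2 (Rattus norvegicus), read by thallium flux, with a stated time of 2.5 min (a lower number here means a smaller maximal response, a higher number a larger maximal response), 93.3%; compound 2 `Cc1c(OCCCCOc2cccc(C(=O)O)c2)ccc(C(=O)CC2CCCC2)c1O` stands nearest with 80.6%, compound 1 `COC(=O)c1ccc(OCCCCOc2ccc(C(=O)CC3CCCC3)c(O)c2C)cc1` furthest with 12.2%. Compound 4 `Cc1cc(OCCCCOc2ccc(C(=O)CC3CCCC3)c(O)c2C)ccc1C(=O)O` differs from compound 3 by cyclopentyl in place of isopropyl on a saturated chain carbon bound to a carbonyl carbon. Going by the values given here, the only measured step, a number 68.4 percentage points higher from compound 1 to compound 2 (beyond the scatter), concerns the aryl acid part, not the chain at the carbonyl, so no measured step bears on this change; compounds 1 and 2 carry cyclopentyl, compound 3 isopropyl, but their aryl parts differ as well. A step within the scatter is therefore expected, a number 5.3 percentage points lower from compound 3 to compound 4 (within the scatter). For compound 4 in this assay the estimate is 88%, with a range from 70% to 100%.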

Compound 4, largest response reached (reported as percent of maximum), in percent of the reference or control that the assay uses: 83.6%
Compound 4: the middle estimate sits 4.4 percentage points above what was measured, and the stated range covers the measured number.
By their numbers in this assay, from the lowest: compound 1; then compounds 2, 4 and 3 (each within the scatter of the next, the first and the last beyond it).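

At the saturated chain carbon bound to a carbonyl carbon, cyclopentyl and isopropyl are not separated in this assay (a number 9.7 percentage points lower from compound 3 to compound 4 (within the scatter)). With cyclopentyl held constant, 4-carboxy-3-methylphenyl and 3-carboxyphenyl on the oxygen are also not separated (a number 3 percentage points higher from compound 2 to compound 4 (within the scatter)), whereas 4-(methoxycarbonyl)phenyl stands well apart (a number 71.4 percentage points higher from compound 1 to compound 4 (beyond the scatter)). No available data explain these steps. Still open, as far as these compounds go, is how a longer chain, a phenyl ring or an amine at this chain carbon would affect the maximal response. Also open, from the compounds shown here alone, is whether a free carboxylic acid is required on the aryl part, or whether an amide could take its place.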